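Chloro to nitro on a phenoxy-linked pyridone

The source may report more compounds than this note shows. Statements on the series, on what has been measured and on what is new or still open speak of the compounds shown alone.

Measured so far in a functional assay on PANC-1 cells (Homo sapiens) for inhibition, read by MTT assay, with a stated time of 24 h, tested at 10 uM; a higher number here means more inhibition at the concentration tested (going by the name of the read-out), a lower number less inhibition:
compound 1 `CC(C)=CCC1Cc2c(OCCCNS(=O)(=O)c3ccc(Cl)cc3)cc(=O)n(CCCO)c2CC1(C)C` gives 9.8%
compound 2 `CC(C)=CCC1Cc2c(OCCCNS(=O)(=O)c3ccc([N+](=O)[O-])cc3)cc(=O)n(CCCO)c2CC1(C)C` gives 17.3%
compound 3 `CC(C)=CCC1Cc2c(OCCCOc3ccc(Cl)cc3)cc(=O)n(CCCO)c2CC1(C)C` gives 0%

Compound 2 differs from compound 1 by nitro in place of chloro on an aromatic carbon, and the step is a number 7.5 percentage points higher from compound 1 to compound 2 (within the scatter). Compound 3 differs from compound 1 in the linker, (4-chlorophenoxy in place of ((4-chlorophenyl)sulfonyl)amino on a saturated chain carbon, three bonds along the chain from an oxygen on an aromatic ring), and the step is a number 9.8 percentage points lower from compound 1 to compound 3 (within the scatter). Compound 3 has the lowest number of the three, but its gap to compound 1 lies within the scatter, so no order between those two is claimed; only compound 2 stands beyond the scatter from compound 3.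

Compound 4 `CC(C)=CCC1Cc2c(OCCCOc3ccc([N+](=O)[O-])cc3)cc(=O)n(CCCO)c2CC1(C)C` is not yet measured. It differs from compound 3 by nitro in place of chloro on an aromatic carbon, the same change as made from compound 1 to compound 2, with the place of the change reading the same in both pairs; the two cores differ as told by 4-chlorophenoxy in place of ((4-chlorophenyl)sulfonyl)amino on a saturated chain carbon, three bonds along the chain from an oxygen on an aromatic ring. For the measured compounds named here, the only precedent is the step of a number 7.5 percentage points higher from compound 1 to compound 2 (within the scatter), which stayed within the scatter. On that basis the step of a number 7 percentage points higher from compound 3 to compound 4 (within the scatter) is expected to be small and of the same sign. Compound 4 is therefore estimated at 7% in this assay, with a range from 0% to 18%.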

Compound 4, a percentage reported as inhibition, at one concentration (the size of the read-out at that concentration, not a potency): 0%
Compound 4: middle estimate off by 7 percentage points, on the high side, and the stated range covers the measured number.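

In this assay the nitro for chloro change on the phenoxy-linked core gives no change at the digits printed from compound 3 to compound 4 (within the scatter) and the full replacement of the sulfonylamino arm gives a number 9.8 percentage points lower from compound 1 to compound 4 (within the scatter). Set beside the earlier step on the sulfonylamino core, the change shows no difference between the two cores that can be told from scatter: the same change on two cores in this assay, a number 7.5 percentage points higher (within the scatter) from compound 1 to compound 2 and no change at the digits printed (within the scatter) from compound 3 to compound 4, 7.5 percentage points apart, within the scatter of two such steps. For the compounds shown here, this does not show that the change is without effect or that it acts alike on both cores, as the comparison rests on only two pairs at a single concentration, with compound 3 at 0% and compound 4 at 0%.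

The compounds shown leave open whether an amine, a carboxylic acid or a nitrile in place of chloro or nitro would give a step beyond the scatter on either core. Also open, going by these compounds, is whether a longer chain in the linker would change the readings on the shared core.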